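A Methyl on the Thiazole of Compound 2

The source may report more compounds than this note shows. Statements on the series, on what has been measured and on what is new or still open speak of the compounds shown alone.

Among the compounds with values here, compound 2 `COc1ccc(-c2cn(CC(=O)Nc3nccs3)nn2)cc1` gives 510 nM in a functional assay on BMDM cells (Mus musculus, strain C57BL/6) for inhibition, with a stated time of 2 days (on this read-out higher numbers stand for weaker inhibition and lower numbers for stronger inhibition), the lowest of the two numbers measured so far. Within the data shown here, its only neighbour, compound 1 `O=C(Cn1cc(-c2ccc([N+](=O)[O-])cc2)nn1)Nc1nccs1`, gives 1040 nM in this assay, and the single measured step, a 2.0-fold lower number from compound 1 to compound 2 (0.31 log units; beyond the scatter), belongs to methoxy in place of nitro on an aromatic carbon. Compound 3 `COc1ccc(-c2cn(CC(=O)Nc3nc(C)cs3)nn2)cc1` is the next compound, and it differs from compound 2 by methyl in place of hydrogen on an aromatic carbon, so that 1,3-thiazol-2-yl becomes 4-methyl-1,3-thiazol-2-yl. Among the measured compounds shown here, no measured step touches this five-membered aromatic ring with 1 nitrogen and 1 sulfur; the step from compound 1 to compound 2 concerns another part of the shared core and offers no guide here. With nothing to point in either direction, the account expects a step of no change at the digits printed from compound 2 to compound 3 (within the scatter), that is, none beyond the scatter. Compound 3 is therefore estimated at 510 nM, with a range from 200 nM to 1300 nM.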

Compound 3, half-maximal inhibitory concentration: 3890 nM
Beside the measured number, compound 3's estimate is 7.6-fold (0.88 log units) below it; measured number outside the range, above it.
By their numbers in this assay, from the lowest: compound 2; then compound 1; then compound 3.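

In this assay, within the data shown here, the first change at this ring, the methyl of the 4-methyl-1,3-thiazol-2-yl group, gives a 7.6-fold higher number from compound 2 to compound 3 (0.88 log units; beyond the scatter) and so weakens inhibition. The carbon next to the ring nitrogen is therefore not indifferent to substitution: even one added heavy atom there moves the number beyond the scatter, and of the two groups compared at this carbon, hydrogen gives the stronger inhibition. Nothing shown here accounts for the size or direction of this step.

On these data alone, whether an ethyl, a chlorine or an amine on this same carbon would raise the number as the methyl does remains open. So does whether the methyl would give a similar step with the nitro group of compound 1 in place of the methoxy.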